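This account rests on a few compounds, and the source may have more. Where it says the series, first, only, none or still open, it means among the compounds named here.

Among the three compounds already measured in a functional assay on MKN-45 cells (Homo sapiens) for cytotoxicity, read by MTT assay, with a stated time of 72 h (a lower number here means a stronger inhibitor, a higher number a weaker inhibitor), compound 3 `COc1cc(/C=N/NC(=O)Nc2ccc(Oc3ccnc(-c4nncn4CCN(C)C)c3)c(F)c2)ccc1O` has the highest number, giving 3780 nM. Its closest neighbour is compound 2 `CN(C)CCn1cnnc1-c1cc(Oc2ccc(NC(=O)N/N=C/c3ccc(O)c(O)c3)cc2F)ccn1`, which gives 3240 nM; the two sit together, as a 1.2-fold higher number from compound 2 to compound 3 (0.07 log units; within the scatter) shows. The furthest is compound 1 `CN(C)CCn1cnnc1-c1cc(Oc2ccc(NC(=O)N/N=C/c3ccccc3O[N+](=O)[O-])cc2F)ccn1`, which gives 1020 nM; the steps away from it are a 3.2-fold higher number from compound 1 to compound 2 (0.50 log units; beyond the scatter) and a 3.7-fold higher number from compound 1 to compound 3 (0.57 log units; beyond the scatter).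

Compound 4 `CN(C)CCn1cnnc1-c1cc(Oc2ccc(NC(=O)N/N=C/c3ccc(O)cc3O)cc2F)ccn1` is the next to be tested. It differs from compound 3 in one place: 2,4-dihydroxyphenyl in place of 4-hydroxy-3-methoxyphenyl on a carbon with a double bond to nitrogen. Two of the measured steps bear on this change. The step of a 1.2-fold higher number from compound 2 to compound 3 (0.07 log units; within the scatter) shows that swapping a hydroxy for a methoxy on this ring moved the number only within the scatter, and compound 2, which like compound 4 carries two hydroxy groups on the ring, stands close to compound 3. The larger steps from compound 1 involve the nitrooxy group, which compound 4 does not carry. Compound 4 is therefore expected to stay near compound 3, with a 1.1-fold lower number from compound 3 to compound 4 (0.03 log units; within the scatter) lying within the scatter, and the estimate for compound 4 in this assay is 3500 nM, between 1500 nM and 8000 nM.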

Compound 4, half-maximal inhibitory concentration: 2860 nM
Compound 4: the middle estimate sits 1.2-fold (0.09 log units) above what was measured; the range from low to high includes it.
By their numbers in this assay, from the lowest: compound 1; then compounds 4, 2 and 3 (each within the scatter of the next).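

In this assay, 2,4-dihydroxyphenyl on this carbon gives a 1.3-fold lower number from compound 3 to compound 4 (0.12 log units; within the scatter) and a 1.1-fold lower number from compound 2 to compound 4 (0.05 log units; within the scatter), so the three rings carrying two oxygen groups in compounds 2, 3 and 4 cannot be told apart here, even with the groups arranged differently on the ring. Compound 1 remains apart, as a 2.8-fold higher number from compound 1 to compound 4 (0.45 log units; beyond the scatter) shows, making compound 4 the third compound separated from the 2-(nitrooxy)phenyl compound by a step beyond the scatter. Nothing available explains this grouping or why compound 1 stands apart.

On these data alone, whether compound 1 stands apart through the nitrooxy group itself or through the absence of a hydroxy group on its ring remains open. Also open, as far as these compounds go, is where an unsubstituted phenyl ring, or a phenyl ring carrying an amine or a carboxylic acid, would fall on this carbon.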